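Ester-side ring change on a kinase inhibitor scaffold

The compounds below may be only part of what the source reports. "The series", "measured", "known", "first", "only" and "open" are said of these compounds alone.

Measured compounds:
- Compound 1, `CCCCCOC(=O)c1cccc(-c2cc(C(=O)Nc3ccncc3)ccc2CN)c1`: 4.9 nM
- Compound 2, `COC(=O)c1cccc(-c2cc(C(=O)Nc3ccncc3F)ccc2CN)c1`: 7.8 nM
- Compound 3, `NCc1ccc(C(=O)Nc2ccncc2)cc1-c1cccc(C(=O)OCC2CCCC2)c1`: 5 nM

All three were tested in an assay on isolated protein for inhibition of Rho-associated protein kinase 2 (Homo sapiens), read by radiometric assay; on this read-out higher numbers stand for weaker inhibition and lower numbers for stronger inhibition. On these numbers compound 2 stands highest of the three, yet its gaps to compound 3 and to compound 1 both lie within the scatter, so the three compounds cannot be told apart on this read-out. Compound 4, `NCc1ccc(C(=O)Nc2ccncc2F)cc1-c1cccc(C(=O)OCC2CC2)c1`, has not been measured. It differs from compound 2 in one place: cyclopropyl in place of hydrogen on a saturated chain carbon bound to an oxygen next to a carbonyl group.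

Going by the values given here, one measured step bears on this change. It alters the same place on the shared core: from compound 1 to compound 3, with cyclopentyl in place of butyl on a saturated chain carbon bound to an oxygen next to a carbonyl group, the result was a 1.0-fold higher number from compound 1 to compound 3 (0.01 log units; within the scatter). Among the compounds with values here, compound 1 and compound 2 differ in two places at once, so their values show only that the two numbers sit within the scatter of each other. Taken together, a change at this position seems to leave this assay largely unmoved. For compound 4 the expected step is therefore a 1.2-fold lower number from compound 2 to compound 4 (0.08 log units; within the scatter), none beyond the scatter. The estimate for compound 4 in this assay is 6.5 nM, with a range from 3 nM to 15 nM.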

Compound 4, half-maximal inhibitory concentration: 2.7 nM
Compound 4: the middle estimate sits 2.4-fold (0.38 log units) above what was measured, outside the stated range (below it).
By their numbers in this assay, from the lowest: compounds 4, 1, 3 and 2 (each within the scatter of the next, the first and the last beyond it).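

In this assay, going by these compounds alone, this position is not silent after all: cyclopropyl in place of hydrogen on the saturated chain carbon bound to an oxygen next to a carbonyl group gave a real gain (a 2.9-fold lower number from compound 2 to compound 4 (0.46 log units; beyond the scatter)), the first step here to clear the scatter. The earlier step (a 1.0-fold higher number from compound 1 to compound 3 (0.01 log units; within the scatter)) exchanged one carbon group at the chain end for another and showed no readable change, whereas going from methyl to cyclopropylmethyl does register, so the methoxycarbonyl of compound 2 can be improved upon. Nothing shown here accounts for the drop in the number, so it stands as an observation without a known cause.

All the compounds shown keep the ester, so it remains open whether a carboxylic acid or an amide at this place would hold the number at this level. On these data alone, it is also open whether the same step from methyl to cyclopropylmethyl would appear on the core of compound 1, which lacks the fluorine carried by compound 2 and compound 4.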